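The compounds below may be only part of what the source reports. "The series", "measured", "known", "first", "only" and "open" are said of these compounds alone.

Measured compounds:
compound 1 `O=C(/C(=C\c1c(O)cc(O)cc1O)S(=O)(=O)c1ccccc1Br)c1ccc(Cl)cc1` — 50000 nM
compound 2 `O=C(/C(=C\c1c[nH]c2ccc(Br)cc12)SCc1ccc(Cl)cc1Cl)c1ccc(Cl)cc1` — 10000 nM
compound 3 `Cc1ccsc1/C=C(/SCc1ccc(Cl)cc1Cl)C(=O)c1ccc(Cl)cc1` — 10000 nM

These three compounds were measured in a functional assay on DU-145 cells (Homo sapiens) for inhibition, read by trypan blue exclusion, with a stated time of 96 h; on this read-out lower numbers stand for stronger inhibition of growth and higher numbers for weaker inhibition of growth. Compound 3 stands level with compound 2 at the digits shown, the two together giving the lowest numbers of the three; compound 1 gives the highest number, which lies beyond the scatter away from compound 3.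

The next compound, compound 4 `O=C(/C(=C\c1c(O)cc(O)cc1O)SCc1ccc(Cl)cc1Cl)c1ccc(Cl)cc1`, has not yet been measured. It differs from compound 3 in one place: 2,4,6-trihydroxyphenyl in place of 3-methylthiophen-2-yl on a double-bonded chain carbon bound to a double-bonded chain carbon.

For the measured compounds named here, only one measured step changes the group in that same place, and it showed no change at the digits printed from compound 2 to compound 3 (within the scatter), so swapping one aromatic group for another there did not move the number. Going by the values given here, the entering group is the one found in compound 1, but compound 1 also differs from compound 3 in a second place, so its higher number cannot be attributed to the entering group alone. Taken together, the data give little reason to expect a large step in either direction, with some lean toward a weaker number.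

Compound 4 is therefore expected to give about 20000 nM, somewhere between 6000 nM and 60000 nM, an estimated step of a 2.0-fold higher number from compound 3 to compound 4 (0.30 log units; within the scatter).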

Compound 4, concentration for 50% growth inhibition: 25000 nM
Compound 4: the middle estimate sits 1.3-fold (0.10 log units) below what was measured; measured number inside the range.
By their numbers in this assay, from the lowest: compounds 2 and 3 (each within the scatter of the next); then compounds 4 and 1 (each within the scatter of the next).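

In this assay, the place on a double-bonded chain carbon bound to a double-bonded chain carbon now proves sensitive to the group it carries: the earlier swap of one aromatic group for another moved nothing readable, whereas 2,4,6-trihydroxyphenyl gives a 2.5-fold higher number from compound 3 to compound 4 (0.40 log units; beyond the scatter) and, against the bromoindole compound, a 2.5-fold higher number from compound 2 to compound 4 (0.40 log units; beyond the scatter) as well. Both steps are modest but beyond the scatter, so of the three groups seen at this place, 2,4,6-trihydroxyphenyl goes with weaker inhibition of growth, at least with (2,4-dichlorobenzyl)sulfanyl as the partner group. For the compounds shown here, compound 4 also gives compound 1 a one-place comparison for the first time, and putting (2,4-dichlorobenzyl)sulfanyl in place of (2-bromophenyl)sulfonyl gives a 2.0-fold lower number from compound 1 to compound 4 (0.30 log units; within the scatter), which stays within the scatter, so no effect of that swap can be read. Nothing measured here explains why the number moves at either place.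

The compounds shown leave open how much of the step rests on the hydroxy groups, since a plain phenyl group at this place would separate them from the ring itself. They also leave open whether an aromatic ring carrying an amine or a carboxylic acid there would sit with compound 3 or with compound 4.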